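Amide headgroup swap on a naphthalene thiazolidinedione series

The compounds below may be only part of what the source reports. "The series", "measured", "known", "first", "only" and "open" are said of these compounds alone.

Measured so far:
Compound 1, `Cc1ccc(NC(=O)COc2ccc3cc(/C=C4/SC(=O)NC4=O)ccc3c2)cc1Cl`, gives > 50000 nM in an assay on isolated protein for inhibition of histone deacetylase 8 (Homo sapiens), with a stated time of 1 h; a lower number here means a stronger inhibitor, a higher number a weaker inhibitor; this is a limit of the assay and not a number.
Compound 2, `O=C(COc1ccc2cc(/C=C3/SC(=O)NC3=O)ccc2c1)Nc1cccc(Cl)c1`, gives > 50000 nM in this assay; this too is a limit.
Compound 3, `Cc1cccc(NC(=O)COc2ccc3cc(/C=C4/SC(=O)NC4=O)ccc3c2)n1`, gives 7500 nM in this assay.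

Compound 3 therefore holds the only number shown: the other two values sit at the limit of > 50000 nM in this assay, at which 2 of the 3 values shown sit. The steps of an at least 6.6-fold lower number from compound 1 to compound 3 (0.82 log units; beyond the scatter) and an at least 6.6-fold lower number from compound 2 to compound 3 (0.82 log units; beyond the scatter) both read as at least modest, but because they start from the limit of > 50000 nM in this assay, at which 2 of the 3 values shown sit, their true size cannot be read; the step that the two limits leave unreadable from compound 1 to compound 2 is unreadable for the same reason.

Compound 4, `Cc1cccc2sc(NC(=O)COc3ccc4cc(/C=C5/SC(=O)NC5=O)ccc4c3)nc12`, is not yet measured. It differs from compound 3 in one place: 4-methyl-1,3-benzothiazol-2-yl in place of 6-methylpyridin-2-yl on an amide-type nitrogen. Among the measured compounds shown here, no measured step bears directly on this change; the only movement seen so far came from replacing a chlorinated phenyl by 6-methylpyridin-2-yl on the amide-type nitrogen. On these data alone, the move to a bicyclic heteroaryl ring is untested here. Compound 4 is therefore expected to stay near compound 3, with a 1.3-fold lower number from compound 3 to compound 4 (0.10 log units; within the scatter) as the expected step. Compound 4 is estimated at 6000 nM, within a range from 1500 nM to 30000 nM.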

Compound 4, half-maximal inhibitory concentration: 5800 nM
For compound 4 the middle estimate is 1.0-fold (0.01 log units) above the measured one, within the range that was stated.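

In this assay, the amide-type nitrogen accepts a five-membered aromatic ring with sulfur and a second ring in 4-methyl-1,3-benzothiazol-2-yl with no real movement from 6-methylpyridin-2-yl: the step is a 1.3-fold lower number from compound 3 to compound 4 (0.11 log units; within the scatter). The separation from the chlorinated phenyl amides now rests on two different heteroaryl groups rather than one, with an at least 8.6-fold lower number from compound 2 to compound 4 (0.93 log units; beyond the scatter) and an at least 8.6-fold lower number from compound 1 to compound 4 (0.93 log units; beyond the scatter). The true size of these two steps cannot be read, and neither can the step between compound 1 and compound 2: the limit of > 50000 nM in this assay, at which 2 of the 4 values shown sit.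

On these data alone, whether the ring nitrogen or the methyl group carries the difference from the chlorinated phenyl amides stays open. A pyridin-2-yl without the methyl, or an unsubstituted phenyl, on the amide-type nitrogen would separate the two.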